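The source may hold more compounds than are shown below. What is called first, only, known or untested is meant among the compounds shown, and "the series" means these compounds.

Measured so far in an ADME assay on the whole organism with Oryza sativa as the target, tested at 0.1 uM; a higher number here means a weaker effect of the compound at the concentration tested, a lower number a stronger effect:

Compound 1, `Cc1ccc(NC(=O)N[C@H](C)c2ccccc2)cc1`: 100%
Compound 2, `CCc1ccccc1NC(=O)N[C@H](C)c1ccccc1`: 101%
Compound 3, `CCc1ccc(NC(=O)N[C@H](C)c2ccccc2)cc1`: 95%

The three measured compounds stand close together. Compound 2 has the highest of the three numbers, with compound 1 nearest and compound 3 furthest, but both gaps are within the scatter, so no order among them can be claimed. The one counted step among them runs from compound 1 to compound 3:

methyl in place of hydrogen on a saturated chain carbon bound to an aromatic carbon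

That step gave a number 5 percentage points lower from compound 1 to compound 3 (within the scatter) in this assay, a change that cannot be told from noise.

Compound 4, `CC(C)c1ccccc1NC(=O)N[C@H](C)c1ccccc1`, has not yet been measured. The difference between the core of compound 2 and the core of compound 1 is not broken down here. Compound 4 is related to compound 2 by a change of the same kind:

methyl in place of hydrogen on a saturated chain carbon bound to an aromatic carbon and a saturated chain carbon

The place is not the same word for word: in compound 2 the carbon that takes the methyl is bound to an aromatic carbon and a saturated chain carbon, whereas in compound 1 it is bound to an aromatic carbon only. Since the earlier step from compound 1 to compound 3 stayed within the scatter, compound 4 is expected to sit near compound 2, with a step of a number 3 percentage points lower from compound 2 to compound 4 (within the scatter) estimated, resting on a number 5 percentage points lower from compound 1 to compound 3 (within the scatter) and on the value of compound 1 being 100% and that of compound 2 being 101%. The estimate for compound 4 is 98%, between 88% and 106%.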

Compound 4, a percentage reported as activity, at one concentration (the size of the read-out at that concentration, not a potency): 103%
Compound 4: the middle estimate sits 5 percentage points below what was measured; measured number inside the range.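

In this assay, the change from ethyl to isopropyl, a methyl in place of hydrogen on a saturated chain carbon bound to an aromatic carbon and a saturated chain carbon, gave a number 2 percentage points higher from compound 2 to compound 4 (within the scatter) and so cannot be told from noise. Set beside the earlier step, the same kind of change on two cores shows no difference that can be claimed: the same change on two cores in this assay, a number 5 percentage points lower (within the scatter) from compound 1 to compound 3 and a number 2 percentage points higher (within the scatter) from compound 2 to compound 4, 7 percentage points apart, within the scatter of two such steps. This shows that, in these two cases, adding the methyl left the number indistinguishable from that of the parent compound on either core, but it does not show that the change has no effect on other cores, and neither step is large enough to reveal a trend that could be carried over.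

The groups shown at this place are only short saturated chains, so what a longer chain, an amine or a carboxylic acid would do remains open. Also open, as far as these compounds go, is whether any change to this series can move the number beyond the scatter.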